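The source may hold more compounds than are shown below. What is called first, only, known or untested is meant among the compounds shown, and "the series" means these compounds.

The compounds here share one core and differ in the group on an amide-type nitrogen. Compound 1 `CCNC(=O)CCc1cccc2c1B(O)OC2` carries ethyl there. In a functional assay on MDA-MB-231 cells (Homo sapiens) for antiproliferative activity, read by MTT assay, with a stated time of 72 h (on this read-out higher numbers stand for weaker inhibition and lower numbers for stronger inhibition), compound 1 gives > 100000 nM, which is a limit of the assay and not a number. Compound 2 `O=C(CCc1cccc2c1B(O)OC2)Nc1ccc(F)cc1` carries 4-fluorophenyl and gives 440 nM, while compound 3 `O=C(CCc1cccc2c1B(O)OC2)Nc1cccc(Br)c1` carries 3-bromophenyl and gives 720 nM. These two values lie within the scatter of each other, so compound 3 stands level with compound 2, and both stand well clear of the limit of compound 1.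

Compound 4 `C#Cc1cccc(NC(=O)CCc2cccc3c2B(O)OC3)c1` has not been measured. It keeps the structure of compound 3 but has ethynyl in place of bromo on an aromatic carbon, meta to a large group (ethynyl in place of bromo on an aromatic carbon).

Two measured steps were large, an at least 220-fold lower number from compound 1 to compound 2 (2.35 log units; beyond the scatter) and an at least 130-fold lower number from compound 1 to compound 3 (2.14 log units; beyond the scatter), but each replaced ethyl with a substituted phenyl, and the new change keeps the phenyl ring. The closer guide is a 1.6-fold higher number from compound 2 to compound 3 (0.21 log units; within the scatter), where changing the groups on that ring moved the number by no more than the scatter. A similarly small result is therefore expected here, with no clear direction. The expected step is a 1.1-fold lower number from compound 3 to compound 4 (0.04 log units; within the scatter). For compound 4, the estimated value is 650 nM, with an expected range from 220 nM to 2000 nM.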

Compound 4, half-maximal inhibitory concentration: 1600 nM
Beside the measured number, compound 4's estimate is 2.5-fold (0.39 log units) below it; the range from low to high includes it.
By their numbers in this assay, from the lowest: compounds 2 and 3 (each within the scatter of the next); then compound 4. At a limit, above all of these: compound 1.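

In this assay, ethynyl in place of bromo on this aromatic carbon gives a 2.2-fold higher number from compound 3 to compound 4 (0.35 log units; beyond the scatter), so a change confined to the group on the phenyl ring can move the number beyond the scatter, which a 1.6-fold higher number from compound 2 to compound 3 (0.21 log units; within the scatter) had not shown. The shift is modest, however, and remains far smaller than an at least 130-fold lower number from compound 1 to compound 3 (2.14 log units; beyond the scatter), so in these compounds, replacing ethyl with a substituted phenyl matters much more than swapping bromo for ethynyl on that ring. Nothing in the available evidence bears on why the ethynyl compound gives the higher number.

This single pair cannot show whether other groups on the same carbon, such as an amine, a carboxylic acid or a longer chain ending in a triple bond, would give a lower or higher number than bromo or ethynyl. It also leaves open whether the same swap would have a similar effect on a ring carrying its group elsewhere, as the 4-fluorophenyl of compound 2 does.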